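Cyclopentyl in place of propyl on an aromatic nitrogen

The source may hold more compounds than are shown below. What is called first, only, known or untested is meant among the compounds shown, and "the series" means these compounds.

In a functional assay on DU-145 cells (Homo sapiens) for inhibition, read by trypan blue exclusion, with a stated time of 72 h (on this read-out lower numbers stand for stronger inhibition and higher numbers for weaker inhibition), compound 1 (`COC(=O)Cn1c(=O)c(S(=O)(=O)c2ccc(F)cc2F)cc2cnc(Nc3ccc4[nH]ccc4c3)nc21`) gives 10000 nM and compound 2 (`CCCn1c(=O)c(S(=O)(=O)c2ccc(F)cc2F)cc2cnc(Nc3ccc4[nH]ccc4c3)nc21`) gives 1000 nM as the lower of the two numbers. The step followed here keeps the shared core and alters the group on the same aromatic nitrogen: compound 3 (`O=c1c(S(=O)(=O)c2ccc(F)cc2F)cc2cnc(Nc3ccc4[nH]ccc4c3)nc2n1C1CCCC1`) has cyclopentyl in place of propyl on an aromatic nitrogen in all. Among the measured compounds shown here, only one measured step bears on this substituent, a 10-fold lower number from compound 1 to compound 2 (1.00 log units; beyond the scatter) and it shows that a change there can move the number beyond the scatter. For the measured compounds named here, no compound with a ring at this nitrogen has been measured, so the direction remains an expectation. In this assay a modest gain is expected, with the estimate being a 3.3-fold lower number from compound 2 to compound 3 (0.52 log units; beyond the scatter) on the lower side. Compound 3 is estimated at 300 nM with a range of 50 nM to 1500 nM expected for it.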

Compound 3, half-maximal inhibitory concentration: 5000 nM
Compound 3: middle estimate off by 17-fold (1.22 log units), on the low side, outside the stated range (above it).
By their numbers in this assay, from the lowest: compound 2; then compounds 3 and 1 (each within the scatter of the next).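

In this assay the ring brought no gain at this aromatic nitrogen: the change gives a 5.0-fold higher number from compound 2 to compound 3 (0.70 log units; beyond the scatter), so a larger carbon group here does not by itself lower the number. Against the (methoxycarbonyl)methyl group, cyclopentyl gives a 2.0-fold lower number from compound 1 to compound 3 (0.30 log units; within the scatter), which leaves these two very different groups indistinguishable on this read-out, while compound 2 alone stands beyond the scatter from both of the others. No evidence at hand accounts for the difference between the propyl chain and the cyclopentyl ring.

The compounds shown leave open whether the chain or the ring is what matters, since isopropyl, butyl and cyclopropyl do not appear among them. They also leave open how an amine or a carboxylic acid at the end of the propyl chain would compare with compound 2.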